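Methoxy for nitro on the aryl ketone series

A few compounds are considered here, and "the series" means these few. Any claim that something is new, unique, unknown or untested is made for them only; others in the source may bear on it.

In a functional assay on HT-29 cells (Homo sapiens) for inhibition, read by WST assay, with a stated time of 48 h (on this read-out higher numbers stand for weaker inhibition and lower numbers for stronger inhibition), compound 3 `O=C(CSc1nc2ccccc2[nH]1)c1ccc([N+](=O)[O-])cc1` gives 57000 nM, the higher of the two plain numbers in the set. Compound 2 `COc1ccc(C(=O)CSc2nc3ccccc3[nH]2)cc1OC`, which carries two methoxy groups, gives 19100 nM in this assay, and the gap between it and compound 3 is beyond the scatter. Compound 1 `CCOc1ccc(C(=O)CSc2nc3ccccc3[nH]2)cc1` gives > 100000 nM in this assay, and this is a limit rather than a number.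

Compound 4 `COc1ccc(C(=O)CSc2nc3ccccc3[nH]2)cc1` differs from compound 3 by methoxy in place of nitro on an aromatic carbon. Among the measured compounds shown here, the only single-point step in the set that touches this position is an at least 1.7-fold lower number from compound 1 to compound 3 (0.24 log units; that floor lies within the scatter), and since compound 1 sits at the limit of > 100000 nM in this assay, at which 1 of the 3 values shown sits, that floor is loose and the step cannot be sized properly. The step from ethoxy to nitro gave no change resolved beyond the scatter, and the swap back to a one-carbon alkoxy group is taken the same way. No step beyond the scatter is therefore expected in this assay, the estimated step being a 1.1-fold lower number from compound 3 to compound 4 (0.06 log units; within the scatter). Compound 4 is thus expected to give about 50000 nM in this assay, with the range running from 15000 nM to 150000 nM, and a real chance that only a limit is reported.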

Compound 4, half-maximal inhibitory concentration: 25200 nM
Estimate against measurement, compound 4: 2.0-fold (0.30 log units) above, and the stated range covers the measured number.
By their numbers in this assay, from the lowest: compounds 2 and 4 (each within the scatter of the next); then compound 3. At a limit, above all of these: compound 1.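

In this assay, methoxy in place of nitro gives a 2.3-fold lower number from compound 3 to compound 4 (0.35 log units; beyond the scatter), a modest step and the first at this position with a plain number at both ends, whereas the earlier step from compound 1 rested on a limit. Hydrogen in place of the further methoxy group of compound 2 gives a 1.3-fold higher number from compound 2 to compound 4 (0.12 log units; within the scatter), so that group has no resolved effect on this read-out. Methoxy in place of ethoxy gives an at least 3.9-fold lower number from compound 1 to compound 4 (0.59 log units; beyond the scatter), which is only a floor and not a measured size, as compound 1 stands at a limit: the limit of > 100000 nM in this assay, at which 1 of the 4 values shown sits.

The compounds shown leave open whether the sharp separation between compound 1 and compound 4 belongs to alkoxy chain length generally, and a propoxy group or a longer chain at the same position would test this. They also leave open how an amine or a carboxylic acid at this position would compare with methoxy and nitro, and whether any group there moves the number much beyond the modest step seen so far.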